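Swapping the Aryl Ketone Group in a Weak Cytotoxic Series

The source may hold more compounds than are shown below. What is called first, only, known or untested is meant among the compounds shown, and "the series" means these compounds.

Among the measured compounds shown here, compound 1 `COc1cc(-c2nnc3n2NC(c2ccco2)C(C(=O)c2ccccc2C)S3)cc(OC)c1OC` is the only compound here with a numeric result in a functional assay on A549 cells (Homo sapiens) for cytotoxicity, read by MTT assay, with a stated time of 48 h (on this read-out lower numbers stand for stronger inhibition and higher numbers for weaker inhibition), where compound 1 gives 80000 nM. Compound 2 `COc1ccc(C(=O)C2Sc3nnc(-c4cc(OC)c(OC)c(OC)c4)n3NC2c2ccco2)cc1` returns only an assay limit, > 100000 nM (the limit of > 100000 nM in this assay, at which 1 of the 2 values shown sits). For the measured compounds named here, the step of an at least 1.2-fold higher number from compound 1 to compound 2 (0.09 log units; that floor lies within the scatter) is the one measured change on the carbonyl-bearing group, and it bears on compound 3 `COc1cc(-c2nnc3n2NC(c2ccco2)C(C(=O)c2ccc(-c4ccccc4)cc2)S3)cc(OC)c1OC`, which differs from compound 1 by 4-phenylphenyl in place of 2-methylphenyl on a carbonyl carbon. Because an at least 1.2-fold higher number from compound 1 to compound 2 (0.09 log units; that floor lies within the scatter) ended at the limit (the limit of > 100000 nM in this assay, at which 1 of the 2 values shown sits), no gain beyond the scatter is expected. Compound 3 is estimated at 100000 nM, within 40000 nM to 250000 nM. That estimate means a step of a 1.3-fold higher number from compound 1 to compound 3 (0.10 log units; within the scatter).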

Compound 3, half-maximal inhibitory concentration: > 100000 nM
Compound 3 gave a limit, no number; the forecaster's own chance of this, stated with the estimate: 55%; the middle value lies on the limit itself.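

Placing 4-phenylphenyl on the carbonyl carbon gives an at least 1.2-fold higher number from compound 1 to compound 3 (0.09 log units; that floor lies within the scatter) in this assay. A second six-membered aromatic ring on this carbon, a bigger change than the earlier swap, therefore brings no readable gain in potency. The step between compound 2 and compound 3 cannot be read because both results are limits, not numbers: the limit of > 100000 nM in this assay, at which 2 of the 3 values shown sit.

From the compounds shown here alone, whether an aminomethyl or carboxylic acid group on this aryl ketone would give a lower number stays open. Going by these compounds, how far compound 2 and compound 3 lie past the limit also stays unknown.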